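The compounds below may be only part of what the source reports. "The series", "measured", "known", "first", "only" and "open" are said of these compounds alone.

In an assay on HEK293 cells for binding affinity to Urotensin-2 receptor (Homo sapiens), read by radioligand binding (a lower number here means a stronger inhibitor, a higher number a weaker inhibitor), compound 1 `CC(C)C[C@H](NC(=O)c1ccc2ccccc2n1)C(=O)N[C@H]1CCN(Cc2ccc(OCCCN(C)C)cc2)C1` gives 631 nM, and compound 2 `CC(C)C[C@H](NC(=O)c1cccs1)C(=O)N[C@H]1CCN(Cc2ccc(OCCCN(C)C)cc2)C1` gives 398 nM; the step of a 1.6-fold lower number from compound 1 to compound 2 (0.20 log units; within the scatter) leaves the two within scatter of each other, so compound 2 cannot be set apart from compound 1 on these numbers. Compound 3 `CC(=O)N[C@@H](CC(C)C)C(=O)N[C@H]1CCN(Cc2ccc(OCCCN(C)C)cc2)C1` carries methyl in place of thiophen-2-yl on a carbonyl carbon. Going by the values given here, only the step from compound 1 to compound 2 bears on this; it shows that exchanging one aromatic group for another changed little, while removing the ring entirely is untested. A weaker number is expected for compound 3, a 3.3-fold higher number from compound 2 to compound 3 (0.51 log units; beyond the scatter), with an estimate of 1300 nM and a range from 400 nM to 4000 nM.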

Compound 3, inhibition constant: 2510 nM
Compound 3: middle estimate off by 1.9-fold (0.29 log units), on the low side; the range from low to high includes it.
By their numbers in this assay, from the lowest: compounds 2 and 1 (each within the scatter of the next); then compound 3.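

Acetamido is the first change at this position to move the number beyond the scatter, with a 6.3-fold higher number from compound 2 to compound 3 (0.80 log units; beyond the scatter) and a 4.0-fold higher number from compound 1 to compound 3 (0.60 log units; beyond the scatter). Among these three compounds, thiophen-2-yl and quinolin-2-yl on the carbonyl carbon both go with lower numbers than methyl, while the two rings remain within scatter of each other. Nothing available explains the difference.

Still open, from the compounds shown here alone, is whether the ring itself matters or whether a non-aromatic group larger than methyl, such as cyclohexyl or a longer alkyl chain, would serve equally well.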